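Replacing a Fluorophenyl Group with a Dimethoxyphenyl Group

A few compounds are considered here, and "the series" means these few. Any claim that something is new, unique, unknown or untested is made for them only; others in the source may bear on it.

Three close relatives of one shared core have been tested in a functional assay on K562 cells (Homo sapiens) for cytotoxicity, read by MTT assay, with a stated time of 48 h; a higher number here means a weaker inhibitor, a lower number a stronger inhibitor. Compound 1 `O=C(CN[C@H]1CCN(S(=O)(=O)Cc2ccccc2)C1)N1CCN(Cc2ccccc2Cl)CC1` gives 9000 nM, compound 2 `O=C(CN[C@H]1CCN(S(=O)(=O)Cc2ccccc2)C1)N1CCN(Cc2ccccc2F)CC1` gives 12600 nM, and compound 3 `O=C(CN[C@H]1CCN(S(=O)(=O)Cc2ccccc2)C1)N1CCN(Cc2c(Cl)cccc2Cl)CC1` gives 28400 nM. Compound 2 therefore stands second highest of the three numbers, with compound 1 nearest to it and compound 3 furthest from it. The step of a 1.4-fold higher number from compound 1 to compound 2 (0.15 log units; within the scatter) shows that fluoro in place of chloro on the aromatic carbon makes no difference beyond the scatter, while a 3.2-fold higher number from compound 1 to compound 3 (0.50 log units; beyond the scatter) and a 2.3-fold higher number from compound 2 to compound 3 (0.35 log units; beyond the scatter) show that a further chloro on this ring modestly weakens the compound in this assay.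

Compound 4 `COc1cc(CN2CCN(C(=O)CN[C@H]3CCN(S(=O)(=O)Cc4ccccc4)C3)CC2)cc(OC)c1` differs from compound 2 in one place: 3,5-dimethoxyphenyl in place of 2-fluorophenyl on a saturated chain carbon bound to an amine nitrogen in a ring. Among the measured compounds shown here, no measured step covers this particular exchange; the closest guides are the halogen swap from compound 1 to compound 2, which lay within the scatter, and the modest weakening seen on going to compound 3. On that basis the number for compound 4 in this assay is expected to stay close to that of compound 2, or drift slightly higher, a step of a 1.2-fold higher number from compound 2 to compound 4 (0.08 log units; within the scatter). Compound 4 is thus estimated at 15000 nM, within a range from 6000 nM to 40000 nM.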

Compound 4, half-maximal inhibitory concentration: 33800 nM
For compound 4 the middle estimate is 2.3-fold (0.35 log units) below the measured one, and the stated range covers the measured number.
By their numbers in this assay, from the lowest: compounds 1 and 2 (each within the scatter of the next); then compounds 3 and 4 (each within the scatter of the next).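

Exchanging the 2-fluorobenzyl group for 3,5-dimethoxybenzyl removes the halogen from this position altogether, and in this assay the change gives a 2.7-fold higher number from compound 2 to compound 4 (0.43 log units; beyond the scatter) and, measured against the chloro analogue, a 3.8-fold higher number from compound 1 to compound 4 (0.57 log units; beyond the scatter) as a second modest weakening. The comparison with the dichlorinated compound gives a 1.2-fold higher number from compound 3 to compound 4 (0.08 log units; within the scatter) and so separates neither group from the other, which means that a ring with no halogen at all and the 2,6-dichlorophenyl ring cannot be told apart here. Across these four compounds the result extends what compound 3 alone suggested: the 2,6-dichlorophenyl and 3,5-dimethoxyphenyl compounds, 3 and 4, both stand beyond the scatter from the monohalogenated compounds 1 and 2, and no compound shown goes against this.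

Nothing offered here accounts for this difference in the numbers. On these data alone, compound 4 changes the kind of group and its place on the ring in one step, so it remains open how a single methoxy group, an unsubstituted benzyl group or a pyridine ring in place of the benzene ring would read at this position.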